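The source may hold more compounds than are shown below. What is called first, only, known or untested is meant among the compounds shown, and "the series" means these compounds.

Of the compounds shown here, three sharing one urea-linked core have been measured in a physicochemical assay for solubility, at pH 7.4; a higher number here means a more soluble compound, a lower number a less soluble compound. Compound 1 `Cc1cc(NC(=O)Nc2ccc(C(=O)O)cc2)c2ccccc2n1` gives 9300 nM. Compound 2 `Cc1cc(NC(=O)Nc2ncccc2C)c2ccccc2n1` gives 1300 nM. Compound 3 `Cc1ccc(NC(=O)Nc2cc(C)nc3ccccc23)cc1` gives 1300 nM. On these numbers compound 3 sits level with compound 2 and together they hold the lowest of the three values, since no change at the digits printed from compound 2 to compound 3 (within the scatter). Compound 1 stands furthest away: a 7.2-fold lower number from compound 1 to compound 3 (0.85 log units; beyond the scatter).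

The next compound, compound 4 `Cc1cc(NC(=O)Nc2ccc(N)cc2)c2ccccc2n1`, has not yet been measured in this assay. Its structure differs from compound 3 in one place: amino in place of methyl on an aromatic carbon. The one measured step that bears on this is the one from compound 1 to compound 3, where a group carrying a hydrogen-bond donor and acceptor left and methyl entered, and the number fell as shown by a 7.2-fold lower number from compound 1 to compound 3 (0.85 log units; beyond the scatter). Within the data shown here, the present change runs the other way, with a donor-and-acceptor group entering in place of methyl, though amino is not carboxy and no measured pair shows that exact swap. A rise of modest size in this assay is therefore expected, smaller than the step involving compound 1.

Compound 4 is expected to give about 3000 nM, within a range from 1300 nM to 7000 nM. The estimated step this implies is a 2.3-fold higher number from compound 3 to compound 4 (0.36 log units; beyond the scatter).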

Compound 4, solubility: 18500 nM
Estimate against measurement, compound 4: 6.2-fold (0.79 log units) below, outside the stated range (above it).
By their numbers in this assay, from the lowest: compounds 2 and 3 (each within the scatter of the next); then compounds 1 and 4 (each within the scatter of the next).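

The position on the six-membered aromatic ring of carbon only, para to a large group, now shows a far larger response in this assay than the modest step (a 7.2-fold lower number from compound 1 to compound 3 (0.85 log units; beyond the scatter)) had suggested: swapping methyl for amino, with one heavy atom leaving and one entering, gives a large step (a 14-fold higher number from compound 3 to compound 4 (1.15 log units; beyond the scatter)). The 4-aminophenyl group also stands clear of 3-methylpyridin-2-yl (a 14-fold higher number from compound 2 to compound 4 (1.15 log units; beyond the scatter)), even though 3-methylpyridin-2-yl and 4-methylphenyl could not be told apart in compound 2 and compound 3. Amino and carboxy on this aromatic carbon cannot be told apart in this assay (a 2.0-fold higher number from compound 1 to compound 4 (0.30 log units; within the scatter)), so the earlier step from carboxy to methyl and the new step from methyl to amino both mark methyl as the group that differs at this position among the three compounds that vary there.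

Nothing at hand gives a reason for the size of the step from methyl to amino. From the compounds shown here alone, it remains open whether a hydroxyl, a methylamino, a dimethylamino or an acetamide group on the same aromatic carbon would stay level with amino and carboxy or fall back towards methyl.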